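Moving the methyl group on the amide-bearing phenyl ring

This account rests on a few compounds, and the source may have more. Where it says the series, first, only, none or still open, it means among the compounds named here.

In an assay on CHO cells with metabotropic glutamate receptor 5 (Homo sapiens) as the target (a higher number here means that more compound is needed for the effect, a lower number that less compound is needed), the three measured compounds stand as follows:
compound 1, `O=C(Nc1cc(-c2ccccc2)nn1-c1ccccc1)c1cccc(Cl)c1`: 40 nM
compound 2, `O=C(Nc1cc(-c2ccccc2)nn1-c1ccccc1)c1cnccn1`: 200 nM
compound 3, `Cc1ccccc1C(=O)Nc1cc(-c2ccccc2)nn1-c1ccccc1`: > 10000 nM

For compound 3 this is a limit of this assay, not a number. Compound 3 is thus the weakest of the three, with an at least 250-fold higher number from compound 1 to compound 3 (2.39 log units; beyond the scatter) and an at least 50-fold higher number from compound 2 to compound 3 (1.69 log units; beyond the scatter), while a 5.0-fold higher number from compound 1 to compound 2 (0.70 log units; beyond the scatter) is modest. Compound 4, `Cc1cccc(C(=O)Nc2cc(-c3ccccc3)nn2-c2ccccc2)c1`, differs from compound 3 by 3-methylphenyl in place of 2-methylphenyl on a carbonyl carbon. Within the data shown here, no measured step shifts a methyl group within the ring, but compound 1 carries 3-chlorophenyl in the same place and gives 40 nM, so a strong recovery is expected, roughly an at least 120-fold lower number from compound 3 to compound 4 (2.09 log units; beyond the scatter). Compound 4 is estimated at 80 nM, within 20 nM to 400 nM.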

Compound 4, half-maximal effective concentration: 90 nM
The estimate for compound 4 lay 1.1-fold (0.05 log units) below the measured number, and the stated range covers the measured number.
By their numbers in this assay, from the lowest: compound 1; then compound 4; then compound 2. At a limit, above all of these: compound 3.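

Moving the methyl group alone, with the same atoms joined differently, gives an at least 110-fold lower number from compound 3 to compound 4 (2.04 log units; beyond the scatter), so in this assay the place of the methyl on this ring separates 2-methylphenyl sharply from 3-methylphenyl. The figure for compound 3 is a limit and not a number: the limit of > 10000 nM in this assay, at which 1 of the 4 values shown sits. Methyl in place of chloro on an aromatic carbon gives only a 2.3-fold higher number from compound 1 to compound 4 (0.35 log units; beyond the scatter), and 3-methylphenyl in place of pyrazin-2-yl gives a 2.2-fold lower number from compound 2 to compound 4 (0.35 log units; beyond the scatter), both small beside the move of the methyl. On these data alone, whether an amine or a longer chain such as propyl in place of that methyl would keep the number of compound 4 stays open.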